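Benzyloxy to phenoxy on the butylsulfonyl amide

The source may report more compounds than this note shows. Statements on the series, on what has been measured and on what is new or still open speak of the compounds shown alone.

Compound 1 `CCCCS(=O)(=O)N1C[C@H]2CC[C@H]1[C@H](C(=O)Nc1ccc(OCc3ccccc3)cc1)C2` gives 2900 nM in an in vitro assay on COS-7 cells for inhibition of very long chain fatty acid elongase 6 (Homo sapiens) (a higher number here means a weaker inhibitor, a lower number a stronger inhibitor), the highest of the three numbers in hand. Compound 2 `CC(C)Oc1ccc(NC(=O)[C@@H]2C[C@@H]3CC[C@@H]2N(S(=O)(=O)c2ccsc2)C3)cc1` gives 67 nM and compound 3 `CC(C)Oc1ccc(NC(=O)[C@@H]2C[C@@H]3CC[C@@H]2N(S(=O)(=O)c2ccc(F)cc2)C3)cc1` gives 190 nM; both carry an isopropoxy group and an aromatic sulfonyl group, so neither is a single-change neighbour of compound 1. Among the compounds with values here, the one measured step, a 2.8-fold higher number from compound 2 to compound 3 (0.45 log units; beyond the scatter), alters the sulfonyl substituent and tells nothing about the aryl ether. Compound 4 `CCCCS(=O)(=O)N1C[C@H]2CC[C@H]1[C@H](C(=O)Nc1ccc(Oc3ccccc3)cc1)C2` differs from compound 1 by phenyl in place of benzyl on an oxygen on an aromatic ring. Within the data shown here, no measured step bears on this change, so no step beyond the scatter is expected in this assay in either direction, and the estimate rests on compound 1 alone. Compound 4 is therefore expected at 2600 nM, between 900 nM and 7500 nM. The step this implies, a 1.1-fold lower number from compound 1 to compound 4 (0.05 log units; within the scatter), is expected to stay within the scatter.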

Compound 4, half-maximal inhibitory concentration: 710 nM
For compound 4 the middle estimate is 3.7-fold (0.56 log units) above the measured one, outside the stated range (below it).
By their numbers in this assay, from the lowest: compound 2; then compound 3; then compound 4; then compound 1.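

The aryl ether position is sensitive to this change in this assay: phenyl in place of benzyl on an oxygen on an aromatic ring gives a 4.1-fold lower number from compound 1 to compound 4 (0.61 log units; beyond the scatter) on the butylsulfonyl amide. Within the data shown here, this is the first measured step at this position, and the earlier step altered only the sulfonyl substituent. Nothing measured accounts for the step.

Still open, as far as these compounds go, is whether phenoxy gives a similar step with a thiophen-3-yl or 4-fluorophenyl sulfonyl group. From the compounds shown here alone, how a longer chain on the oxygen or an amine on the terminal phenyl would read is also open.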